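Swapping one small ring for another on a sulfonyl linker

The source may hold more compounds than are shown below. What is called first, only, known or untested is meant among the compounds shown, and "the series" means these compounds.

Measured so far:
- compound 1, `O=S(=O)(CC1=NCCO1)c1c(-c2ccccc2)nn(-c2ccccc2)c1-c1ccccc1`: 55.6%
- compound 2, `O=S(=O)(CC1=NCCS1)c1c(-c2ccccc2)noc1-c1ccccc1`: "not active" (no number reported)
- compound 3, `COc1ccc(C2=NOC(c3ccc(C)cc3)C2S(=O)(=O)CC2=NCCO2)cc1`: 65.9%

In a functional assay, tested at 50 ug/mL (a higher number here means a stronger effect of the compound at the concentration tested, a lower number a weaker effect), compound 3 gives 65.9%, the highest of the two numbers reported; compound 1 gives 55.6%, a value beyond the scatter below it. Compound 2 gives "not active" (no number reported), with no number attached. Compound 1 and compound 2 differ in more than one place, so their contrast cannot be tied to any single change.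

Compound 4, `COc1ccc(C2=NOC(c3ccc(C)cc3)C2S(=O)(=O)CC2=NCCS2)cc1`, is not yet measured. It differs from compound 3 in one place: a group of 5 heavy atoms (3 carbon, 1 nitrogen, 1 sulfur; one five-membered non-aromatic ring with 2 hetero atoms) in place of a group of 5 heavy atoms (3 carbon, 1 nitrogen, 1 oxygen; one five-membered non-aromatic ring with 2 hetero atoms), on a saturated chain carbon bound to a sulfonyl sulfur. Within the data shown here, the only other pair in which a ring with 1 oxygen faces a ring with 1 sulfur is compound 1 against compound 2, and that pair also differs elsewhere. A step from compound 3 to compound 4 in this assay is therefore hard to size; a moderate drop is expected, with a real chance of no reported number. Compound 4 is expected to show 45%, within 15% to 70%, an estimated change of a number 20.9 percentage points lower from compound 3 to compound 4 (beyond the scatter).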

Compound 4, a percentage reported as activity, at one concentration (the size of the read-out at that concentration, not a potency): 47.5%
Compound 4: middle estimate off by 2.5 percentage points, on the low side; the measured number falls inside the stated range.
By their numbers in this assay, from the lowest: compounds 4 and 1 (each within the scatter of the next); then compound 3.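

Among these compounds, compound 3 and compound 4 give the first comparison here that isolates this change: in this assay replacing the oxygen-containing five-membered ring with its sulfur-containing counterpart, on a saturated chain carbon bound to a sulfonyl sulfur, gives a number 18.4 percentage points lower from compound 3 to compound 4 (beyond the scatter). The two rings have the same heavy-atom count and the same numbers of hydrogen-bond donors and acceptors, yet this single exchange lowers the read-out, although compound 4 still gives a reported number on this core. No measurement shown explains why the sulfur ring gives the lower read-out.

From the compounds shown here alone, whether the step would have a similar size on the core of compound 1 remains open. So does how an open-chain amine or a carboxylic acid would behave at this place.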